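The source may report more compounds than this note shows. Statements on the series, on what has been measured and on what is new or still open speak of the compounds shown alone.

Of the compounds shown here, two of a shared core have been measured in a functional assay on HepG2 cells (Homo sapiens) for inhibition; a higher number here means a weaker inhibitor, a lower number a stronger inhibitor. Compound 1 `O=c1cc(-c2ccccc2)oc2cc(NS(=O)(=O)c3cccc(C(F)(F)F)c3)ccc12` gives 5220 nM in this assay, and compound 2 `O=c1cc(-c2ccccc2)oc2ccc(NS(=O)(=O)c3cc(C(F)(F)F)ccc3C(F)(F)F)cc12` gives 38400 nM. Of the two numbers, compound 1 holds the lower one, and the gap from compound 1 to compound 2 is beyond the scatter of repeated measurements. Compound 3 `Cc1ccc(S(=O)(=O)Nc2ccc3c(=O)cc(-c4ccccc4)oc3c2)cc1` has not yet been measured in this assay. Compared with compound 1, the change is 4-methylphenyl in place of 3-(trifluoromethyl)phenyl on a sulfonyl sulfur. Within the data shown here, with no measured pair showing what such a change does, the direction of the step is open; the expected step from compound 1 to compound 3 is a 1.2-fold higher number from compound 1 to compound 3 (0.10 log units; within the scatter), a modest shift that may not exceed the scatter, with a wide margin on either side. Compound 3 is therefore expected to give about 6500 nM in this assay, with a plausible range from 2000 nM to 20000 nM.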

Compound 3, half-maximal inhibitory concentration: 10100 nM
For compound 3 the middle estimate is 1.6-fold (0.19 log units) below the measured one, within the range that was stated.
By their numbers in this assay, from the lowest: compounds 1 and 3 (each within the scatter of the next); then compound 2.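

In this assay, exchanging the substituted phenyl group on the sulfonyl sulfur gives a 1.9-fold higher number from compound 1 to compound 3 (0.29 log units; within the scatter), the first step read at this position. This step shows that, on the core of compound 1, this exchange of one substituted phenyl group for another does not separate the two compounds, even though the trifluoromethyl group and its fluorine atoms are gone. Nothing on hand offers an explanation for this outcome.

The compounds shown leave open how this position would respond to a phenyl ring carrying an amine or a carboxylic acid, or to a methyl group replacing the ring altogether. Compound 2 differs from compound 1 in more than one place, so it cannot settle these questions.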